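An Isomer of Compound 2 Awaits Its Reading

The source may hold more compounds than are shown below. What is called first, only, known or untested is meant among the compounds shown, and "the series" means these compounds.

This account concerns a physicochemical assay for solubility, with a stated time of 3 days, at pH 2 (on this read-out lower numbers stand for lower solubility and higher numbers for higher solubility), and three compounds sharing one core. Compound 1 `NC(=O)c1ccc2[nH]c(-c3ccc(OCC4CCCNC4)cc3)nc2c1` has no usable result, its entry being "not determined" (no result reported). Compound 2 `CC(=O)N1CCCCC1CCOc1ccc(-c2nc3cc(C(N)=O)ccc3[nH]2)cc1` reads > 400000 nM, which is a limit of this assay and not a number. Going by the values given here, its exact position is therefore unknown, and no measured step exists to serve as a guide. Compound 3 `CC(=O)N1CCC(CCOc2ccc(-c3nc4cc(C(N)=O)ccc4[nH]3)cc2)CC1` has the same atoms as compound 2, joined differently: 1-acetylpiperidin-4-yl in place of 1-acetylpiperidin-2-yl on a saturated chain carbon, two bonds along the chain from an oxygen on an aromatic ring. It carries 1-acetylpiperidin-4-yl in place of 1-acetylpiperidin-2-yl on a saturated chain carbon, two bonds along the chain from an oxygen on an aromatic ring. A small downward change is expected, possibly none beyond the usual scatter, and the estimated step is an at least 1.3-fold lower number from compound 2 to compound 3 (0.12 log units; that floor lies within the scatter). For compound 3 the expected value is 300000 nM, with an estimated range from 100000 nM to 400000 nM.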

Compound 3, solubility: 87000 nM
For compound 3 the middle estimate is 3.4-fold (0.54 log units) above the measured one; the measured number lies below the stated range.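

In this assay, the exchange of 1-acetylpiperidin-2-yl for 1-acetylpiperidin-4-yl, on a saturated chain carbon, two bonds along the chain from an oxygen on an aromatic ring, comes with an at least 4.5-fold lower number from compound 2 to compound 3 (0.66 log units; beyond the scatter), so the two isomers do not read alike and this series now has its first single number. For compound 2, the entry of > 400000 nM is a limit of the assay and not a number. The step can therefore be given only as a floor, because compound 2 sits at that limit: the limit of > 400000 nM in this assay, at which 1 of the 3 values shown sits.

As far as these compounds go, the true distance between the two isomers stays open, and steps involving compound 1 cannot be read. Also open, from the compounds shown here alone, is where a longer chain, or a carboxylic acid in place of the acetyl group, would fall on this read-out.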